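The source may hold more compounds than are shown below. What is called first, only, known or untested is meant among the compounds shown, and "the series" means these compounds.

Compound 1 `Nc1c(C(=O)N/N=C/c2ccccc2)oc2nc(-c3ccccc3)cc(C(F)(F)F)c12` gives 70000 nM in an ADME assay on HEK293 cells (Homo sapiens) for antiproliferative activity, read by MTT assay; on this read-out higher numbers stand for weaker inhibition and lower numbers for stronger inhibition.
Compound 2 `Nc1c(C(=O)N/N=C/c2ccccc2)oc2nc(-c3cccs3)cc(C(F)(F)F)c12` gives 72000 nM in this assay.
Compound 3 `Cc1ccc(/C=N/NC(=O)c2oc3nc(-c4ccccc4)cc(C(F)(F)F)c3c2N)cc1` gives 69000 nM in this assay.

Compound 2 sits within the scatter of both other compounds: a 1.0-fold higher number from compound 1 to compound 2 (0.01 log units; within the scatter), and a 1.0-fold lower number from compound 1 to compound 3 (0.01 log units; within the scatter) likewise. Compound 4 `CNC(=O)c1oc2nc(-c3cccs3)cc(C(F)(F)F)c2c1N` differs from compound 2 in this way: one carbon atom in place of a group of 8 heavy atoms (7 carbon, 1 nitrogen; one six-membered aromatic ring of carbon only), on an amide-type nitrogen. Neither measured step touches the amide-type nitrogen; both concern an aromatic carbon, and both stay within the scatter, so the series gives no direct guide to this change. The working assumption is therefore that the number stays near that of compound 2, with a wide range to reflect the unknown position. Compound 4 is expected to give 70000 nM in this assay, between 25000 nM and 200000 nM, which means an expected 1.0-fold lower number from compound 2 to compound 4 (0.01 log units; within the scatter).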

Compound 4, half-maximal inhibitory concentration: 75000 nM
Estimate against measurement, compound 4: 1.1-fold (0.03 log units) below; low and high end bracket the measured number.
By their numbers in this assay, from the lowest: compounds 3, 1, 2 and 4 (each within the scatter of the next).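

On the amide-type nitrogen, methyl can replace the whole group of 8 heavy atoms, with its six-membered aromatic ring and its double bond outside aromatic rings, and the number in this assay stays within the scatter (a 1.0-fold higher number from compound 2 to compound 4 (0.02 log units; within the scatter)). Within the data shown here, the earlier steps touched only an aromatic carbon, so this is the first reading at this nitrogen, and it shows that this large cut leaves no visible mark on the read-out. No measurement at hand offers an explanation for this.

As far as these compounds go, whether a longer chain or a carboxylic acid on the amide-type nitrogen would give a number beyond the scatter stays open. Also open, from the compounds shown here alone, is whether methyl at this place gives the same reading with phenyl in place of thiophen-2-yl.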